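The source may hold more compounds than are shown below. What is called first, only, known or untested is meant among the compounds shown, and "the series" means these compounds.

Three compounds share one core and differ only in the group that sits on the aromatic ring bearing the tert-butyl group. Compound 1 `CCCOc1cc(C(C)(C)C)ccc1C/N=C(\S)NCc1ccc(NS(C)(=O)=O)cc1` carries a propoxy chain and in a functional assay for inhibition of Vanilloid receptor (Rattus norvegicus) (a lower number here means a stronger inhibitor, a higher number a weaker inhibitor), gives 250 nM. Compound 2 `CCCCCOc1cc(C(C)(C)C)ccc1C/N=C(\S)NCc1ccc(NS(C)(=O)=O)cc1` carries a pentyloxy chain and in this assay gives 70 nM. Compound 3 `CC(C)(C)c1ccc(C/N=C(\S)NCc2ccc(NS(C)(=O)=O)cc2)c(OCc2ccccc2)c1` carries a benzyloxy group and in this assay gives 770 nM, the highest of the three numbers. Two steps lead to compound 3: a 3.1-fold higher number from compound 1 to compound 3 (0.49 log units; beyond the scatter) and an 11-fold higher number from compound 2 to compound 3 (1.04 log units; beyond the scatter), so replacing a chain by a ring-bearing group at this position has raised the number each time. Compound 4 `CC(=O)OCc1cc(C(C)(C)C)ccc1C/N=C(\S)NCc1ccc(NS(C)(=O)=O)cc1` is the next variation: acetoxymethyl in place of benzyloxy on an aromatic carbon. The entering group has no ring, like the chains of compound 1 and compound 2, but it is also not a chain bound through an oxygen on the ring, so neither step applies directly. A move back toward a lower number seems more likely than a further rise, and the estimate for compound 4 is 450 nM, within 120 nM to 1800 nM. This estimate means an expected step of a 1.7-fold lower number from compound 3 to compound 4 (0.23 log units; within the scatter).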

Compound 4, half-maximal inhibitory concentration: 580 nM
Compound 4: middle estimate off by 1.3-fold (0.11 log units), on the low side; low and high end bracket the measured number.
By their numbers in this assay, from the lowest: compound 2; then compound 1; then compounds 4 and 3 (each within the scatter of the next).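

Taking the aromatic ring out of this position does not by itself bring the number back down: in this assay, acetoxymethyl in place of benzyloxy gives a 1.3-fold lower number from compound 3 to compound 4 (0.12 log units; within the scatter). The chains keep their lead over this ring-free group, with an 8.3-fold higher number from compound 2 to compound 4 (0.92 log units; beyond the scatter) and a 2.3-fold higher number from compound 1 to compound 4 (0.37 log units; beyond the scatter), so among these four compounds the two plain chains bound through oxygen, propoxy and pentyloxy, give lower numbers than both other groups, and having no ring is not enough to match them. Nothing available here explains these differences.

From the compounds shown here alone, it remains open whether a methoxymethyl group, which has no carbonyl, would fall nearer compound 4 or the chains. Also open, going by these compounds, is whether a hexyloxy or longer chain would lower the number beyond that of pentyloxy.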